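The source may report more compounds than this note shows. Statements on the series, on what has been measured and on what is new or still open speak of the compounds shown alone.

Measured so far in a physicochemical assay for lipophilicity; on this read-out higher numbers stand for higher lipophilicity and lower numbers for lower lipophilicity:
compound 1, `COC(C)(C)CCCC(C)C/C=C/C(C)=C/C(=O)OC(C)(C)C`, 6.36
compound 2, `C#CCCOC(=O)/C=C(C)/C=C/CC(C)CCCC(C)(C)OC`, 5.2
compound 3, `C#CCSC(=O)/C=C(C)/C=C/CC(C)CCCC(C)(C)OC`, 5.9

Compound 3 stands second highest of the three numbers on this assay: compound 1 lies above it, as a number 0.46 log units lower from compound 1 to compound 3 (beyond the scatter) shows, and compound 2 lies below it, as a number 0.70 log units higher from compound 2 to compound 3 (beyond the scatter) shows. The unmeasured compound 4 is `COC(C)(C)CCCC(C)C/C=C/C(C)=C/C(=O)CC(C)C`. Its change from compound 3 is isobutyl in place of propargylsulfanyl on a carbonyl carbon. Going by the values given here, no measured step swaps a group on the carbonyl carbon for a plain alkyl chain; the nearest guides are the steps on that carbon, a number 0.46 log units lower from compound 1 to compound 3 (beyond the scatter) and a number 0.70 log units higher from compound 2 to compound 3 (beyond the scatter), both modest, and the large step of a number 1.16 log units lower from compound 1 to compound 2 (beyond the scatter). Taken together they show that what sits on the carbonyl carbon moves this assay by modest to large amounts, and an isobutyl with no hydrogen-bond acceptor is expected to move it upward. Compound 4 is therefore estimated at 6.4, within 5.9 to 6.9. This estimate means a step of a number 0.50 log units higher from compound 3 to compound 4 (beyond the scatter), expected to lie beyond the scatter.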

Compound 4, partition coefficient: 6.02
Compound 4: the middle estimate sits 0.38 log units above what was measured; the measured number falls inside the stated range.
By their numbers in this assay, from the lowest: compound 2; then compounds 3 and 4 (each within the scatter of the next); then compound 1.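

In this assay, going by these compounds alone, the carbonyl carbon carries a plain alkyl group for the first time, and isobutyl in place of propargylsulfanyl, a swap that removes the sulfur and the triple bond, gives a number 0.12 log units higher from compound 3 to compound 4 (within the scatter) and leaves compound 3 and compound 4 unseparated on this read-out. The direction of the change at this carbonyl carbon depends on the group that leaves, since isobutyl gives a number 0.82 log units higher from compound 2 to compound 4 (beyond the scatter) when it replaces (but-3-yn-1-yl)oxy but a number 0.34 log units lower from compound 1 to compound 4 (beyond the scatter) when it replaces tert-butoxy. Nothing available explains these differences.

The compounds shown leave open how an amine, a carboxylic acid or a chain longer than isobutyl on this carbonyl carbon would read. On these data alone, they also vary only this one place, so changes elsewhere on the shared core remain unexplored.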